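The source may report more compounds than this note shows. Statements on the series, on what has been measured and on what is new or still open speak of the compounds shown alone.

Measured compounds:
compound 1 `COc1cc(C)[nH]c(=O)c1CN1CCc2c(Cl)cc(-c3c(C)noc3C)c(Cl)c2C1=O` — 70 uL/min
compound 2 `Cc1cc(C)c(CN2CCc3c(Cl)cc([C@H](CO)[C@@H]4CCCO4)c(Cl)c3C2=O)c(=O)[nH]1` — 37.6 uL/min

In an ADME assay on microsomes from liver (Homo sapiens) for metabolic stability, read by LC-MS, using NADPH, with stated times of 10 min and 45 min, tested at 1 uM (on this read-out lower numbers stand for slow clearance and higher numbers for fast clearance), compound 1 gives the higher of the two numbers recorded so far; compound 2 gives 37.6 uL/min, and the gap between the two lies within the usual scatter, so no order between them can be read. Compound 3 `COc1cc(C)[nH]c(=O)c1CN1CCc2c(Cl)cc([C@@H](O)C3COC3)c(Cl)c2C1=O` has not been measured. It differs from compound 1 by a group of 6 heavy atoms (4 carbon, 2 oxygen; one four-membered non-aromatic ring with 1 hetero atom) in place of a group of 7 heavy atoms (5 carbon, 1 nitrogen, 1 oxygen; one five-membered aromatic ring with 2 hetero atoms), on an aromatic carbon. Among the measured compounds shown here, no step of this kind is recorded, so the expectation rests on the two values alone. A downward step is expected in this assay, of about a 2.2-fold lower number from compound 1 to compound 3 (0.34 log units; beyond the scatter), possibly no more than the scatter. Compound 3 is estimated at 32 uL/min, within a range of 12 uL/min to 70 uL/min.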

Compound 3, intrinsic clearance in a liver preparation (reported as CLH), per the amount of preparation that the assay uses in the liver assay: < 7 uL/min
Compound 3: only a limit was reported; the forecaster's own chance of this, stated with the estimate: 10%; middle value at least 4.5-fold (0.66 log units) away from the limit.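

Among the compounds shown here, in the liver assay, replacing 3,5-dimethyl-1,2-oxazol-4-yl on this aromatic carbon with the group carrying the four-membered non-aromatic ring gives an at least 10-fold lower number from compound 1 to compound 3 (1.00 log units; beyond the scatter), the first readable step at this position. The entry for compound 3 is a limit of the assay, not a number. In a physicochemical assay for lipophilicity, at pH 7.4 (on this read-out lower numbers stand for lower lipophilicity and higher numbers for higher lipophilicity), compound 1 gives 2.7 and compound 3 gives 1.3, a gap beyond the usual scatter.

On these data alone, whether the clearance step follows the distribution coefficient or the particular group stays open, with both moving together in a single pair. An amine or a carboxylic acid on this carbon lies outside the compounds shown.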